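This account rests on a few compounds, and the source may have more. Where it says the series, first, only, none or still open, it means among the compounds named here.

Measured compounds:

Compound 1, `CC#CCn1c(N2CCC[C@@H](N)C2)nc2c1c(=O)n(Cc1ccc(Br)cc1C(=O)O)c(=O)n2C`. In an ADME assay on isolated protein for inhibition of Dipeptidyl peptidase 9 (Homo sapiens), with stated times of 15 min, 60 s and 20 min (on this read-out higher numbers stand for weaker inhibition and lower numbers for stronger inhibition), compound 1 gives > 100000 nM, which is a limit of the assay and not a number.

Compound 2, `CC#CCn1c(N2CCC[C@@H](N)C2)nc2c1c(=O)n(Cc1cc(OC)ccc1C(=O)O)c(=O)n2C`. In this assay compound 2 gives > 100000 nM, again only a limit.

Compound 3, `CC#CCn1c(N2CCC[C@@H](N)C2)nc2c1c(=O)n(Cc1cc(Cl)ccc1C(=O)OC)c(=O)n2C`. In this assay compound 3 gives > 100000 nM, once more a limit.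

Compound 3 therefore has no definite place among the numbers shown: all three values sit at the limit of > 100000 nM in this assay, at which 3 of the 3 values shown sit, so no compound can be set above or below another. The change to compound 4, `CC#CCn1c(N2CCC[C@@H](N)C2)nc2c1c(=O)n(Cc1cccc(F)c1C(=O)OC)c(=O)n2C`, is 3-fluoro-2-(methoxycarbonyl)phenyl in place of 5-chloro-2-(methoxycarbonyl)phenyl on a saturated chain carbon bound to an aromatic nitrogen. The steps that touch the same place are a step that the two limits leave unreadable from compound 1 to compound 3, a step that the two limits leave unreadable from compound 2 to compound 3 and a step that the two limits leave unreadable from compound 1 to compound 2; none of them can be read, so they give neither a size nor a direction for the present step. With the whole set at the limit, there is no ground to expect a step beyond the scatter in this assay. Compound 4 is expected to give about 150000 nM, within 50000 nM to 500000 nM. The step that the limit leaves unreadable from compound 3 to compound 4 that this estimate means is expected to be none beyond the scatter, most likely reported again as a limit.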

Compound 4, half-maximal inhibitory concentration: > 100000 nM
Compound 4: only a limit was reported; the forecaster's own chance of this, stated with the estimate: 85%; the middle value is on the limit's open side.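

In this assay compound 4 gives > 100000 nM as a limit of the assay and not a number . Within the data shown here, no step from compound 4 to compound 1, compound 2 or compound 3 can be read, as the whole set stands at one limit: the limit of > 100000 nM in this assay, at which 4 of the 4 values shown sit. The compounds shown leave open how strongly any of them inhibits the enzyme and whether any of these group changes alters that inhibition.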